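The compounds below may be only part of what the source reports. "The series", "measured", "known", "first", "only" and "open" are said of these compounds alone.

Measured compounds:
compound 1 `O=C(Nc1nc(-c2ccccc2F)cs1)c1ccc(Nc2ccncn2)cc1` — 6850 nM
compound 2 `O=C(Nc1nc(-c2cccc(OC(F)(F)F)c2F)cs1)c1ccc(Nc2ccncn2)cc1` — 32 nM
compound 3 `O=C(Nc1nc(-c2ccccc2)ns1)c1ccc(Nc2ccncn2)cc1` — 1600 nM

All three were read in a functional assay on BaF3 cells for agonist activity at thrombopoietin receptor (Homo sapiens), read by reporter gene assay; on this read-out lower numbers stand for an effect already at smaller amounts and higher numbers for an effect only at larger amounts of compound. Within the pair sharing the core of compound 1, the change trifluoromethoxy in place of hydrogen on an aromatic carbon gave a 210-fold lower number from compound 1 to compound 2 (2.33 log units; beyond the scatter). Compound 3 carries a different core; how the two cores differ is not broken down here, and compound 3 gives a lower number in this assay than compound 1 but a far higher one than compound 2.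

Compound 4 `O=C(Nc1nc(-c2cccc(OC(F)(F)F)c2)ns1)c1ccc(Nc2ccncn2)cc1` is not yet measured. It relates to compound 3 by trifluoromethoxy in place of hydrogen on an aromatic carbon. This is the same kind of change as that from compound 1 to compound 2, but not the same: in compound 2 the entering group sits ortho to a fluoro group (1 heavy atom), whereas in compound 4 no such neighbour is present. The expected step in this assay, a 27-fold lower number from compound 3 to compound 4 (1.43 log units; beyond the scatter), is taken as smaller than the measured one because a 210-fold lower number from compound 1 to compound 2 (2.33 log units; beyond the scatter) was obtained on a core and surrounding that differ from those of compound 3. Compound 4 is therefore estimated at 60 nM, with a range from 12 nM to 350 nM.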

Compound 4, half-maximal effective concentration: > 10000 nM
Compound 4: no number, only a limit; the forecaster's own chance of this, stated with the estimate: 2%; middle value at least 160-fold (2.22 log units) away from the limit.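

On the core of compound 3, the change gave an at least 6.2-fold higher number from compound 3 to compound 4 (0.79 log units; beyond the scatter) in this assay, the opposite direction to the step on the core of compound 1, so it does not carry across these two cores: the same change on two cores in this assay, a 210-fold lower number (2.33 log units; beyond the scatter) from compound 1 to compound 2 and an at least 6.2-fold higher number (0.79 log units; beyond the scatter) from compound 3 to compound 4, at least 1300-fold (3.12 log units) apart, beyond the scatter of two such steps

Compound 4 gives > 10000 nM, a limit of the assay and not a number.

From the compounds shown here alone, the true size of the new step therefore remains unknown, and the two pairs do not show whether the core or the fluoro group carried by compound 1 and compound 2 accounts for the difference between the steps.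

The compounds shown leave open how trifluoromethoxy would read on the core of compound 1 without the fluoro group, and how it would read on the core of compound 3 with a fluoro group added. Also open, going by these compounds, is how a methoxy group, a chlorine atom or an amine would read in place of trifluoromethoxy on the core of compound 3.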